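The source may report more compounds than this note shows. Statements on the series, on what has been measured and on what is new or still open speak of the compounds shown alone.

In a functional assay on MCF7 cells (Homo sapiens) for cytotoxicity, read by ELISA, with a stated time of 4 days (a lower number here means a stronger inhibitor, a higher number a weaker inhibitor), compound 1 `Clc1ccc(-c2cc(-c3ccoc3)cc(-c3ccco3)n2)s1` gives 4740 nM and compound 2 `Clc1ccc(-c2cc(-c3ccoc3)cc(-c3cccnc3)n2)s1` gives 3480 nM, so the two values lie within the scatter of each other. Compound 3 `Clc1ccc(-c2cc(-c3ccco3)nc(-c3ccc(Cl)s3)c2)o1` keeps the rest of compound 1 but changes the group opposite the ring nitrogen: 5-chlorofuran-2-yl in place of furan-3-yl on an aromatic carbon, with 5-chlorofuran-2-yl in place of furan-3-yl. Going by the values given here, only one measured step is available, a 1.4-fold lower number from compound 1 to compound 2 (0.13 log units; within the scatter), which is within the scatter. It replaces furan-2-yl with pyridin-3-yl, at a different place from the present change, so it bears only indirectly. Among the compounds with values here, no measured compound shows what happens on changing the group opposite the ring nitrogen, and none shows the effect of adding chlorine to a furan. An estimated step of a 1.4-fold lower number from compound 1 to compound 3 (0.13 log units; within the scatter) is therefore expected in this assay, which is no change beyond the scatter, with a wide margin. Compound 3 is expected at about 3500 nM, within an estimated range of 1300 nM to 9000 nM.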

Compound 3, half-maximal inhibitory concentration: 16900 nM
For compound 3 the middle estimate is 4.8-fold (0.68 log units) below the measured one; the whole stated range lies below it.
By their numbers in this assay, from the lowest: compounds 2 and 1 (each within the scatter of the next); then compound 3.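

In this assay the position opposite the ring nitrogen proves responsive, with a 3.6-fold higher number from compound 1 to compound 3 (0.55 log units; beyond the scatter) for 5-chlorofuran-2-yl in place of furan-3-yl. Going by these compounds alone, the only earlier step, made at the furan-2-yl group, was a 1.4-fold lower number from compound 1 to compound 2 (0.13 log units; within the scatter) and so gave no change beyond the scatter, which makes this the first replacement on the shared core to show one. Its direction is towards a weaker inhibitor, so this replacement brings no gain at this position.

The compounds shown leave open whether the chlorine or the change from furan-3-yl to a furan-2-yl attachment accounts for the step, and how this position would respond to an amine or a carboxylic acid. No measurement at hand bears on the reason for the step.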